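Aryl swap on the saturated carbon: compound 2 to compound 3

A few compounds are considered here, and "the series" means these few. Any claim that something is new, unique, unknown or untested is made for them only; others in the source may bear on it.

Measured so far:
compound 2, `Cc1cc(C)c(C(Nc2ccccn2)c2ccc3cccnc3c2O)c(C)c1`: 190 nM
compound 1, `Oc1cc2c(cc1C(c1ccc(F)cc1)N1CCCCC1)CCC2`: > 30000 nM (a limit of the assay, not a number)

In an assay for inhibition of protein disulfide-isomerase (Homo sapiens), with a stated time of 1 h (on this read-out lower numbers stand for stronger inhibition and higher numbers for weaker inhibition), compound 2 gives 190 nM. Compound 1 reaches only a limit in this assay, > 30000 nM, so it contributes no number. Among the compounds with values here, compound 2 therefore stands as the only numbered value, the other entry being a limit (the limit of > 30000 nM in this assay, at which 1 of the 2 values shown sits). Within the data shown here, no pair of measured compounds differs in a single place, so no measured step exists for this assay.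

Compound 3, `Oc1c(C(Nc2ccccn2)c2ccccc2F)ccc2cccnc12`, differs from compound 2 by 2-fluorophenyl in place of 2,4,6-trimethylphenyl on a saturated chain carbon bound to an aromatic carbon and a nitrogen on an aromatic ring. Without a measured step, the expectation rests on the change alone; a shift toward weaker inhibition, probably beyond the usual scatter, is expected, of size a 4.7-fold higher number from compound 2 to compound 3 (0.68 log units; beyond the scatter). Compound 3 is estimated at 900 nM, within a range of 150 nM to 6000 nM.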

Compound 3, half-maximal inhibitory concentration: 470 nM
The estimate for compound 3 lay 1.9-fold (0.28 log units) above the measured number; measured number inside the range.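

Within the data shown here, this is the first measured step: in this assay, 2-fluorophenyl in place of 2,4,6-trimethylphenyl on the saturated chain carbon gives a 2.5-fold higher number from compound 2 to compound 3 (0.39 log units; beyond the scatter). Both groups are six-membered aromatic rings of carbon only, without hydrogen-bond donors or acceptors, so the position accepts a change in the ring's substituents with a modest loss and still gives a number rather than a limit. Nothing measured here accounts for the size of this step.

The compounds shown leave open whether the step follows from the fluorine entering or from the methyl groups leaving, a question that plain phenyl or 2-methylphenyl on this carbon would address. Also open, from the compounds shown here alone, is how a saturated ring such as cyclohexyl, or a phenyl carrying an amine or a carboxylic acid, would read at this position.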